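The compounds below may be only part of what the source reports. "The series", "measured", "known", "first", "only" and "open" are said of these compounds alone.

Of the compounds shown here, three share one core and have been tested in a functional assay on DLD-1 cells (Homo sapiens) for inhibition, read by MTT assay, with a stated time of 72 h; on this read-out lower numbers stand for stronger inhibition and higher numbers for weaker inhibition. Compound 3 `COc1ccc(CNCc2c(OC)cc(Oc3cccc(Nc4ccccc4)c3)cc2OC)cc1` gives 1910 nM and so has the lowest of the two numbers recorded. Compound 1 `COc1cc(Oc2cccc(Nc3ccccc3)c2)cc(OC)c1CNCCNC(C)=O` gives 6010 nM in this assay. For compound 2 `COc1cc(Oc2cccc(Nc3ccccc3)c2)cc(OC)c1CNC(C)C` the result in this assay is only a limit, > 20000 nM, not a number. The measured steps all concern the group on the amine nitrogen: a 3.1-fold lower number from compound 1 to compound 3 (0.50 log units; beyond the scatter), an at least 10-fold lower number from compound 2 to compound 3 (1.01 log units; beyond the scatter), and an at least 3.3-fold higher number from compound 1 to compound 2 (0.52 log units; beyond the scatter), the last resting on (the limit of > 20000 nM in this assay, at which 1 of the 3 values shown sits).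

Compound 4 `COc1cc(Oc2cccc(Nc3ccccc3)c2)cc(OC)c1CNCc1ccc(O)cc1` changes compound 3 elsewhere: hydrogen in place of methyl on an oxygen on an aromatic ring. Going by the values given here, none of the measured steps touches an oxygen on an aromatic ring, so they give no direct guide to this change; they only show that the part of the molecule carrying the 4-methoxyphenyl tolerates variation. With no step of this kind in hand, a change of compound 3 to compound 4 of no more than the usual scatter is expected, a 1.3-fold higher number from compound 3 to compound 4 (0.12 log units; within the scatter), in either direction. Compound 4 is therefore estimated at 2500 nM in this assay, within a range from 1000 nM to 6000 nM.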

Compound 4, half-maximal inhibitory concentration: 2690 nM
For compound 4 the middle estimate is 1.1-fold (0.03 log units) below the measured one, and the stated range covers the measured number.
By their numbers in this assay, from the lowest: compounds 3 and 4 (each within the scatter of the next); then compound 1. At a limit, above all of these: compound 2.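

In this assay, going by these compounds alone, replacing the methyl on the oxygen with hydrogen gives a 1.4-fold higher number from compound 3 to compound 4 (0.15 log units; within the scatter), so this is the first evidence at this oxygen and methoxy and hydroxy cannot be told apart here. The methyl is therefore not needed for the lower number seen with a substituted benzyl group on the amine nitrogen, since the hydroxy form still shows a 2.2-fold lower number from compound 1 to compound 4 (0.35 log units; beyond the scatter). The comparison with the isopropyl compound gives only a minimum size, an at least 7.4-fold lower number from compound 2 to compound 4 (0.87 log units; beyond the scatter), and it rests on a limit rather than a number: the limit of > 20000 nM in this assay, at which 1 of the 4 values shown sits.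

Going by these compounds, it remains open whether an unsubstituted benzyl group, with no oxygen on the ring, would keep this level. The same applies to an amine or a carboxylic acid in place of the hydroxy group, or to a longer chain on the oxygen.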